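The compounds below may be only part of what the source reports. "The series", "measured", "known", "first", "only" and "open" are said of these compounds alone.

Compound 1 `Cc1ccc(-c2cc(/N=C3/NC(=O)CS3)cs2)cc1` sits at a limit in a functional assay on MDA-MB-231 cells (Homo sapiens) for cytotoxicity, read by MTT assay, with a stated time of 72 h (on this read-out lower numbers stand for stronger inhibition and higher numbers for weaker inhibition), and gives no number, only > 50000 nM. Compound 2 `O=C1CS/C(=N\c2csc(-c3ccccc3)c2)N1` likewise returns a limit in this assay, > 50000 nM. The step between them, a step that the two limits leave unreadable from compound 1 to compound 2, cannot be sized, since the limit of > 50000 nM in this assay, at which 2 of the 3 values shown sit, holds both ends. For the measured compounds named here, compound 3 `CN(C)c1ccc(/C=C2\S/C(=N\c3csc(-c4ccc(Cl)cc4)c3)NC2=O)cc1` is the only member of the series with a real number in this assay, giving 800 nM. Compound 4 `O=C1N/C(=N/c2csc(-c3ccc(Cl)cc3)c2)S/C1=C\c1ccccn1` differs from compound 3 by pyridin-2-yl in place of 4-(dimethylamino)phenyl on a double-bonded chain carbon bound to a double-bonded ring carbon. Going by the values given here, no measured step touches this change; the single recorded step, a step that the two limits leave unreadable from compound 1 to compound 2, concerns another position and has no readable size, so the expected step of a 3.8-fold higher number from compound 3 to compound 4 (0.57 log units; beyond the scatter) is set as a moderate loss with wide uncertainty. Compound 4 is accordingly estimated at 3000 nM, within 600 nM to 20000 nM.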

Compound 4, half-maximal inhibitory concentration: 10900 nM
Beside the measured number, compound 4's estimate is 3.6-fold (0.56 log units) below it; the measured number falls inside the stated range.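

In this assay, the group on the double-bonded chain carbon bound to a double-bonded ring carbon matters: pyridin-2-yl in place of 4-(dimethylamino)phenyl gives a 14-fold higher number from compound 3 to compound 4 (1.13 log units; beyond the scatter). For the compounds shown here, this is the first step with a readable size, as the step from compound 1 to compound 2 cannot be read between its two limits. No measurement shown gives a cause for this step.

As far as these compounds go, it remains open whether the dimethylamino group or the carbon-only ring goes with the lower number of compound 3. A plain phenyl, a pyridin-4-yl or a 4-methoxyphenyl at this place would bear on that question.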